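Swapping a Ureido for a Cyclic Imide on a Shared Core

The source may hold more compounds than are shown below. What is called first, only, known or untested is meant among the compounds shown, and "the series" means these compounds.

Compound 1 `C=CCNC(=S)NC1=C(C#N)C(c2ccc(Cl)cc2Cl)C2=C(CCCC2=O)N1c1ccc(S(N)(=O)=O)cc1`: 30% in a functional assay on Ehrlich cells (Mus musculus) for cytotoxicity, read by trypan blue exclusion, with a stated time of 2 h, tested at 25 ug/mL; a higher number here means a stronger effect of the compound at the concentration tested, a lower number a weaker effect
Compound 2 `N#CC1=C(NC(=S)Nc2ccccc2)N(c2ccc(S(N)(=O)=O)cc2)C2=C(C(=O)CCC2)C1c1ccc(Cl)cc1Cl`: 50%
Compound 3 `N#CC1=C(NC(N)=O)N(c2ccc(S(N)(=O)=O)cc2)C2=C(C(=O)CCC2)C1c1ccc(Cl)cc1Cl`: 35%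

Compound 3 stands second highest of these three: compound 1 lies within the scatter of it, while compound 2 sits beyond the scatter above it. Compound 4 `N#CC1=C(N2C(=O)CCC2=O)N(c2ccc(S(N)(=O)=O)cc2)C2=C(C(=O)CCC2)C1c1ccc(Cl)cc1Cl` differs from compound 3 in one place, (2,5-dioxopyrrolidin-1-yl in place of ureido on a double-bonded ring carbon). Two measured steps alter the same site: a number 5 percentage points higher from compound 1 to compound 3 (within the scatter) and a number 15 percentage points lower from compound 2 to compound 3 (beyond the scatter). The larger, ring-bearing group of compound 2 gave the higher number, so a modest rise is expected for compound 4 when the ureido gives way to a ring, a number 8 percentage points higher from compound 3 to compound 4 (within the scatter). Compound 4 is therefore estimated at 43%, within a range of 25% to 60%.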

Compound 4, a percentage reported as activity, at one concentration (the size of the read-out at that concentration, not a potency): 50%
The estimate for compound 4 lay 7 percentage points below the measured number; low and high end bracket the measured number.
By their numbers in this assay, from the lowest: compounds 1 and 3 (each within the scatter of the next); then compounds 2 and 4 (each within the scatter of the next).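

In this assay the change from ureido to 2,5-dioxopyrrolidin-1-yl gives a number 15 percentage points higher from compound 3 to compound 4 (beyond the scatter), so a five-membered non-aromatic ring with no hydrogen-bond donors is tolerated at this position. Compared with the phenyl-bearing group, it gives no change at the digits printed from compound 2 to compound 4 (within the scatter), showing that an aromatic ring is not needed here to reach that level. Compared with the ringless allyl-bearing group, it gives a number 20 percentage points higher from compound 1 to compound 4 (beyond the scatter), so among these four compounds, the two with a ring in this group share the higher level. Nothing available explains these steps. As far as these compounds go, whether a plain amine or a six-membered piperidine-2,6-dione at this position would match compound 4 remains open.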